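The source may hold more compounds than are shown below. What is called first, only, known or untested is meant among the compounds shown, and "the series" means these compounds.

Measured in an ADME assay on microsomes from liver (Mus musculus) for metabolic stability; on this read-out higher numbers stand for fast clearance and lower numbers for slow clearance:
- compound 1 `CC(C)c1noc(-c2cccc(CNc3ccc4[nH]nc(C(=O)O)c4c3)c2O)n1`: 38.1 mL/min/kg
- compound 2 `CC(C)c1csc(-c2cccc(CN(C)c3ccc4[nH]nc(C(=O)O)c4c3)c2O)n1`: 13 mL/min/kg
- compound 3 `Cc1nc(-c2cccc(CNc3ccc4[nH]nc(C(=O)O)c4c3)c2O)sc1C`: 15 mL/min/kg

Compound 1 sits at the top of the three numbers in this assay; compound 3 is nearest and compound 2 furthest, both with lower numbers beyond the scatter.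

Compound 4 `Cc1csc(-c2cccc(CNc3ccc4[nH]nc(C(=O)O)c4c3)c2O)n1` is the unmeasured member. The change from compound 1 is 4-methyl-1,3-thiazol-2-yl in place of 3-isopropyl-1,2,4-oxadiazol-5-yl on an aromatic carbon.

Going by the values given here, the one measured step that bears on this is the change in the same place on the shared core: a 2.5-fold lower number from compound 1 to compound 3 (0.40 log units; beyond the scatter). Compound 2 carries a different partner group and a further change on the shared core, so it does not isolate this step, but its number is also well under compound 1. The entering 4-methyl-1,3-thiazol-2-yl and the 4,5-dimethyl-1,3-thiazol-2-yl of compound 3 differ by one methyl only, so a step of about the size seen from compound 1 to compound 3 is expected, towards slower clearance. For compound 4 the expected step is a 2.4-fold lower number from compound 1 to compound 4 (0.38 log units; beyond the scatter). Compound 4 is estimated at 16 mL/min/kg, with a range from 8 mL/min/kg to 32 mL/min/kg in this assay.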

Compound 4, clearance: 34 mL/min/kg
Beside the measured number, compound 4's estimate is 2.1-fold (0.33 log units) below it; measured number outside the range, above it.
By their numbers in this assay, from the lowest: compounds 2 and 3 (each within the scatter of the next); then compounds 4 and 1 (each within the scatter of the next).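

In this assay, a 1.1-fold lower number from compound 1 to compound 4 (0.05 log units; within the scatter), so on this aromatic carbon, ortho to the hydroxy group, 4-methyl-1,3-thiazol-2-yl and 3-isopropyl-1,2,4-oxadiazol-5-yl cannot be told apart. The lower number of the 4,5-dimethyl-1,3-thiazol-2-yl compound therefore does not follow from replacing the oxadiazole by a thiazole alone: a 2.3-fold higher number from compound 3 to compound 4 (0.36 log units; beyond the scatter), and that pair differs only by hydrogen in place of one methyl on the thiazole ring. Nothing at hand explains why this single methyl carries the step.

As far as these compounds go, whether an ethyl, a chlorine or a trifluoromethyl in place of that methyl would give a number like that of compound 3 remains open. Also open, from the compounds shown here alone, is whether the same methyl step would hold with a carboxamide in place of the carboxylic acid on the shared core.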